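Thiazole for Methylphenyl on the Amide of Compound 3

This account rests on a few compounds, and the source may have more. Where it says the series, first, only, none or still open, it means among the compounds named here.

Measured compounds:
- compound 1, `COc1cccc(OCC(=O)Nc2cccc(NC(=O)c3ccc(N(C)C)cc3)c2)c1`: > 10000 nM
- compound 2, `COc1cc(OCC(=O)Nc2cccc(NC(=O)c3ccc(N(C)C)cc3)c2)ccc1C=O`: 3740 nM
- compound 3, `Cc1ccc(C(=O)Nc2cccc(NC(=O)COc3ccc4c(=O)ccoc4c3)c2)cc1`: 183 nM

Of the compounds shown here, three built on a shared core have been tested in an assay on isolated protein for inhibition of Rho-associated protein kinase 1 (Homo sapiens), read by scintillation counting, radiometric assay and 33P incorporation, with a stated time of 40 min, in the presence of a further agent that is not named here; a higher number here means a weaker inhibitor, a lower number a stronger inhibitor. Compound 1 gives only the limit > 10000 nM, which is a boundary of this assay and not a number (the limit of > 10000 nM in this assay, at which 1 of the 3 values shown sits). Compound 2 carries a formyl group where compound 1 has hydrogen. In this assay compound 2 gives 3740 nM, and the step of an at least 2.6-fold lower number from compound 1 to compound 2 (0.42 log units; beyond the scatter) is beyond the scatter. Compound 3 gives 183 nM in this assay, the lowest of the two numbers, below that of compound 2.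

The next compound, compound 4 `Cc1nc(C(=O)Nc2cccc(NC(=O)COc3ccc4c(=O)ccoc4c3)c2)cs1`, differs from compound 3 in one place: 2-methyl-1,3-thiazol-4-yl in place of 4-methylphenyl on a carbonyl carbon. Within the data shown here, none of the measured steps touches this part of the molecule, since the step from compound 1 to compound 2 concerns a different ring, so there is no direct guide for the size or direction of this change. Replacing one aromatic ring by another of similar size often leaves the number within the usual scatter, and the expected step is therefore a 1.4-fold higher number from compound 3 to compound 4 (0.14 log units; within the scatter), without a clear direction. Compound 4 is expected to give about 250 nM in this assay, estimated within the range 80 nM to 800 nM.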

Compound 4, half-maximal inhibitory concentration: 473 nM
Compound 4: the middle estimate sits 1.9-fold (0.28 log units) below what was measured; measured number inside the range.
By their numbers in this assay, from the lowest: compound 3; then compound 4; then compound 2. At a limit, above all of these: compound 1.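

Replacing 4-methylphenyl with 2-methyl-1,3-thiazol-4-yl on the carbonyl carbon gives, in this assay, a 2.6-fold higher number from compound 3 to compound 4 (0.41 log units; beyond the scatter). Among these compounds, this is the first measured sign that this position responds to the choice of ring: the step is modest, and the entering five-membered ring, which carries hydrogen-bond acceptors where the leaving ring has none, does not match the 4-methylphenyl group. A single swap changes the ring size and the hetero atoms together, so the two cannot be separated here, and nothing measured in this set bears on the reason for the step.

Still open, from the compounds shown here alone, is how a pyridine ring, or a phenyl ring carrying a carboxylic acid in place of the methyl, would behave on this carbonyl carbon. Also open, going by these compounds, is whether an ethyl or longer chain in place of the methyl on the thiazole would bring the number back towards that of compound 3, at 183 nM.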